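Cytotoxicity limits in the series, and compound 4

This account rests on a few compounds, and the source may have more. Where it says the series, first, only, none or still open, it means among the compounds named here.

- compound 1 `Cc1ccc(S(=O)(=O)NN2C(=S)S/C(=C\c3ccc(Cl)c(Cl)c3)C2O)cc1`: > 100000 nM (limit)
- compound 2 `O=C1/C(=C/c2ccc(Cl)c(Cl)c2)SC(=S)N1NS(=O)(=O)c1cccs1`: > 100000 nM (limit)
- compound 3 `O=C1/C(=C/c2ccccc2F)SC(=S)N1NS(=O)(=O)c1ccccc1`: > 100000 nM (limit)

In a functional assay on HFF cells (Homo sapiens) for cytotoxicity (a higher number here means a weaker inhibitor, a lower number a stronger inhibitor), compound 3 gives > 100000 nM, which is a limit and not a number. The wider picture is the limit of > 100000 nM in this assay, at which 3 of the 3 values shown sit. Compound 4 `O=C1/C(=C/c2ccc(Cl)c(F)c2)SC(=S)N1NS(=O)(=O)c1ccccc1` differs from compound 3 in one place: 4-chloro-3-fluorophenyl in place of 2-fluorophenyl on a double-bonded chain carbon bound to a double-bonded ring carbon. Among the compounds with values here, no step between measured compounds is available to size this change. The expected step is a number no higher from compound 3 to compound 4 (the limit leaves the size open), with no move in either direction expected beyond the scatter. For compound 4 the estimate is 100000 nM, with an expected range of 50000 nM to 200000 nM.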

Compound 4, half-maximal inhibitory concentration: > 100000 nM
Compound 4: no number, only a limit; the forecaster's own chance of this, stated with the estimate: 85%; the middle value lies on the limit itself.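

The results for compound 3 and compound 4 in this assay are both limits and not numbers, so no step can be read between them. The compounds shown leave open whether replacing 2-fluorophenyl with 4-chloro-3-fluorophenyl changes the half-maximal inhibitory concentration at all.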